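The source may report more compounds than this note shows. Statements on the series, on what has been measured and on what is new or still open speak of the compounds shown alone.

Series notes. Compound 1 `CC1(C)[C@H]2CC[C@]1(C)N(Cc1cn(-c3ccc(C#N)cc3)nn1)C(=O)C2` gives 50 nM in a functional assay on HepG2 cells (Homo sapiens) for inhibition, read by MTT assay, with a stated time of 24 h; a lower number here means a stronger inhibitor, a higher number a weaker inhibitor. Compound 2 `CC1(C)[C@H]2CC[C@]1(C)N(Cc1cn(-c3ccc(Br)cc3)nn1)C(=O)C2` gives 110 nM in this assay, and compound 3 `CC1(C)[C@H]2CC[C@]1(C)N(Cc1cn(-c3ccccc3F)nn1)C(=O)C2` gives 60 nM in this assay, which stands second highest of the three numbers; the steps of a 1.2-fold higher number from compound 1 to compound 3 (0.08 log units; within the scatter) and a 1.8-fold lower number from compound 2 to compound 3 (0.26 log units; within the scatter) are both within the scatter, so the aryl swaps measured so far separate little. Only a 2.2-fold higher number from compound 1 to compound 2 (0.34 log units; beyond the scatter) exceeds the scatter. Compound 4 `CC1(C)[C@H]2CC[C@]1(C)N(Cc1cn(-c3ccc(O)cc3)nn1)C(=O)C2` differs from compound 3 by 4-hydroxyphenyl in place of 2-fluorophenyl on an aromatic nitrogen. Among the measured compounds shown here, no hydroxyphenyl analogue has been measured, and the aryl variations seen sit in a narrow band. The step of a 1.2-fold higher number from compound 3 to compound 4 (0.07 log units; within the scatter) is therefore expected to be small, with no clear direction. Compound 4 is estimated at 70 nM in this assay, with a range of 30 nM to 180 nM.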

Compound 4, half-maximal inhibitory concentration: 80 nM
For compound 4 the middle estimate is 1.1-fold (0.06 log units) below the measured one; the measured number falls inside the stated range.
By their numbers in this assay, from the lowest: compounds 1, 3, 4 and 2 (each within the scatter of the next, the first and the last beyond it).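

Working notes: 4-hydroxyphenyl, which brings a hydrogen-bond donor onto the aryl group, leaves compound 4 within the scatter of all three earlier compounds in this assay: a 1.3-fold higher number from compound 3 to compound 4 (0.12 log units; within the scatter) and a 1.4-fold lower number from compound 2 to compound 4 (0.14 log units; within the scatter) and a 1.6-fold higher number from compound 1 to compound 4 (0.20 log units; within the scatter). Among the compounds shown here, compound 4 therefore does not separate compound 1 from compound 2, the only pair printed beyond the scatter. Nothing available bears on why this change moves the number so little.

Still open, as far as these compounds go, is whether an amine or a carboxylic acid in place of the hydroxy group would give a step beyond the scatter, and whether 2-hydroxyphenyl would read like 4-hydroxyphenyl.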